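This account rests on a few compounds, and the source may have more. Where it says the series, first, only, none or still open, it means among the compounds named here.

Measured compounds:
Compound 1: `COc1ccc(-c2cn(/N=C/c3cc4cc(C)ccc4nc3Cl)c(N)n2)cc1` — > 50000 nM
Compound 2: `Nc1nc(-c2cccs2)cn1/N=C/c1cc2ccccc2nc1Cl` — 7220 nM

In a functional assay on HCT-116 cells (Homo sapiens) for cytotoxicity, read by MTT assay, with a stated time of 48 h (a higher number here means a weaker inhibitor, a lower number a stronger inhibitor), compound 1 gives > 50000 nM, which is a limit of the assay and not a number. Compound 2, with its thienyl group on the shared core, gives 7220 nM in this assay. That is the only number shown; the remaining value sits at the limit of > 50000 nM in this assay, at which 1 of the 2 values shown sits. Compound 1 and compound 2 differ in more than one place, so their two values show only that one falls at the limit and the other gives a number.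

Compound 3 is `Cc1ccc2nc(Cl)c(/C=N/n3cc(-c4cccs4)nc3N)cc2c1`. It differs from compound 2 by methyl in place of hydrogen on an aromatic carbon, on the six-membered carbon ring of the fused system, away from the aminopyrazole and thienyl parts of the core. Going by the values given here, no measured pair shows what such a methyl does here. The change is small and sits on the ring shared by all three compounds, so no step beyond the scatter is expected, in either direction. Compound 3 is therefore estimated at 7500 nM, with a range of 3000 nM to 20000 nM. This estimate means an expected step of a 1.0-fold higher number from compound 2 to compound 3 (0.02 log units; within the scatter), within the scatter.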

Compound 3, half-maximal inhibitory concentration: 7710 nM
Compound 3: middle estimate off by 1.0-fold (0.01 log units), on the low side, within the range that was stated.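

In this assay, going by these compounds alone, methyl in place of hydrogen on the six-membered aromatic ring of carbon only gives a 1.1-fold higher number from compound 2 to compound 3 (0.03 log units; within the scatter), the first single-place comparison, and it shows no change in the read-out beyond the scatter. Compound 1 sits at a limit of the assay and not a number: the limit of > 50000 nM in this assay, at which 1 of the 3 values shown sits. From the compounds shown here alone, with the methyl present on both sides, thiophen-2-yl in place of 4-methoxyphenyl on an aromatic carbon gives an at least 6.4-fold lower number from compound 1 to compound 3 (0.81 log units; beyond the scatter), which ties a step beyond the scatter to this change alone, although its full size stays unknown.

The compounds shown leave open whether a carboxylic acid or a dimethylamino group on the same ring carbon would also stay within the scatter, as one methyl does, and whether the methyl would behave the same way with 4-methoxyphenyl on the core. They also leave open whether the gain belongs to thiophen-2-yl itself or would also appear with an unsubstituted phenyl or a furan-2-yl group in that place.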